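This account rests on a few compounds, and the source may have more. Where it says the series, first, only, none or still open, it means among the compounds named here.

Compound 1 `O=c1cc(CNCc2cccc(Cl)c2)oc2ccc(O)c(O)c12` – in an ADME assay on Huh-7 cells (Homo sapiens) for cytotoxicity (a higher number here means that more compound is tolerated, a lower number that less compound is tolerated), compound 1 gives > 100000 nM, a limit.
Compound 2 `O=c1cc(CNCc2ccc(Br)cc2)oc2ccc(O)c(O)c12` – in this assay compound 2 gives > 100000 nM, a limit.

Compound 2 sits at the limit of > 100000 nM in this assay, at which 2 of the 2 values shown sit, so only a limit is known for it. Compound 3 `Cc1ccc(CNCc2cc(=O)c3c(O)c(O)ccc3o2)cc1` differs from compound 2 by methyl in place of bromo on an aromatic carbon. Among the measured compounds shown here, the one measured step, a step that the two limits leave unreadable from compound 1 to compound 2, cannot be sized, since both ends are limits. No readable step therefore guides the change from compound 2 to compound 3, and a step that the limit leaves unreadable from compound 2 to compound 3 is expected, with a limit again the likely outcome. Compound 3 is estimated at 150000 nM, in a range from 50000 nM to 500000 nM.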

Compound 3, half-maximal cytotoxic concentration: > 100000 nM
Compound 3 ended at the assay's limit (the forecaster's own chance of this, stated with the estimate: 80%); the middle value is on the limit's open side.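

Compound 1, compound 2 and compound 3 all end at a limit, so no step between them can be read: the limit of > 100000 nM in this assay, at which 3 of the 3 values shown sit.

The compounds shown leave open how much of each is actually tolerated in this assay, and so whether exchanging these groups changes anything.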